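The source may hold more compounds than are shown below. What is called first, only, known or untested is meant among the compounds shown, and "the series" means these compounds.

Working notes on the shared core. In a functional assay on CHO cells for activation of 5-hydroxytryptamine receptor 1D (Homo sapiens), read by GTPgammaS binding (a lower number here means a smaller maximal response, a higher number a larger maximal response), compound 1 `c1cc(CNC2CCN(CCCc3c[nH]c4ccc(-n5cnnc5)cc34)CC2)co1` gives 65%. Compound 2 `OC[C@H](NC1CCN(CCCc2c[nH]c3ccc(Cn4cncn4)cc23)CC1)c1ccccc1`, which carries a different substituent on the core and a different amine partner, gives in this assay the value 76%; this lies above the value of compound 1 by a difference beyond the scatter, so compound 1 stands lowest of the two numbers in hand. Compound 3 `CC(CO)(NC1CCN(CCCc2c[nH]c3ccc(-n4cnnc4)cc23)CC1)c1ccccc1` keeps the core of compound 1 and differs from it at the amine only: 1-(hydroxymethyl)-1-phenylethyl in place of (furan-3-yl)methyl on an amine nitrogen. Among the measured compounds shown here, no measured pair isolates this exchange, so its effect in this assay is not known from the data; the two numbers in hand differ only modestly, and the partner of compound 3 resembles that of compound 2 more than that of compound 1. The step from compound 1 to compound 3 is therefore expected to be small and upward, a number 7 percentage points higher from compound 1 to compound 3 (within the scatter), though a result within the scatter would not surprise. Compound 3 is estimated at 72%, with a range of 58% to 86%.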

Compound 3, largest response reached (reported as efficacy), in percent of the reference or control that the assay uses: 59%
Compound 3: the middle estimate sits 13 percentage points above what was measured; low and high end bracket the measured number.
By their numbers in this assay, from the lowest: compounds 3 and 1 (each within the scatter of the next); then compound 2.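

In this assay, among the compounds shown here, 1-(hydroxymethyl)-1-phenylethyl in place of (furan-3-yl)methyl on an amine nitrogen gives a number 6 percentage points lower from compound 1 to compound 3 (within the scatter) and is the only measured step that isolates this position with the core held fixed. The two groups differ in aromatic ring, heavy-atom count and hydrogen-bond donor count, yet the maximal responses of the two compounds lie within the scatter of each other. Nothing in hand gives a reason for this result.

Compound 2 differs from both compounds in more than one place, so its number cannot be assigned to either the amine partner or the core substituent. Open, from the compounds shown here alone, is what a plain benzyl group on this amine nitrogen would give, and whether the hydroxymethyl or the phenyl of the new group matters for the maximal response.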